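Amino-to-fluoro swap on the pyridine arm of the series

A few compounds are considered here, and "the series" means these few. Any claim that something is new, unique, unknown or untested is made for them only; others in the source may bear on it.

Measured compounds:
- compound 1, `COc1ccc(-c2ccc(F)c(C(=O)Nc3c[nH]nc3C(=O)Nc3ccc(F)cc3)c2F)cn1`: "not determined" (no result reported) in a functional assay on A2058 cells (Homo sapiens) for antiproliferative activity, read by luminescence and CellTiter-Glo, with a stated time of 96 h; a lower number here means a stronger inhibitor, a higher number a weaker inhibitor
- compound 2, `Nc1ccc(-c2ccc(F)c(C(=O)Nc3c[nH]nc3C(=O)Nc3ccc(F)cc3)c2F)cn1`: 8540 nM

Within the data shown here, compound 2 carries the only number in hand; compound 1 gives "not determined" (no result reported) in this assay, so no comparison between the two can be drawn. In this assay compound 2 gives 8540 nM, a weak inhibitor on its own terms.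

Compound 3, `O=C(Nc1ccc(F)cc1)c1n[nH]cc1NC(=O)c1c(F)ccc(-c2ccc(F)nc2)c1F`, is the next entry and is not yet measured. Its difference from compound 2 is fluoro in place of amino on an aromatic carbon, which reads as 6-aminopyridin-3-yl to 6-fluoropyridin-3-yl when cut one bond further out. Among the measured compounds shown here, no pair of measured compounds gives a step of this kind, so there is no reference for its size. The step of a 1.2-fold higher number from compound 2 to compound 3 (0.07 log units; within the scatter) is therefore expected to stay close to the scatter, with no firm direction. For compound 3 the estimate is 10000 nM, with a range from 3000 nM to 30000 nM.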

Compound 3, half-maximal inhibitory concentration: 6310 nM
Compound 3: the middle estimate sits 1.6-fold (0.20 log units) above what was measured, and the stated range covers the measured number.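

In this assay, replacing amino with fluoro on the pyridine arm, 6-aminopyridin-3-yl to 6-fluoropyridin-3-yl, gives a 1.4-fold lower number from compound 2 to compound 3 (0.13 log units; within the scatter). At this carbon, next to the ring nitrogen, the hydrogen-bond donor and acceptor counted for amino can leave with no shift beyond the scatter, so compound 2 and compound 3 read as equivalent here. Nothing in hand explains this result or links it to a property of either group.

On these data alone, compound 1, with methoxy on the same carbon, gives "not determined" (no result reported), so the effect of methoxy remains open. Also open, as far as these compounds go, is whether a hydroxyl, a methyl or a dimethylamino group at this carbon would move the number beyond the scatter.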